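Moving the trifluoromethyl group on the hydrazone ring

This account rests on a few compounds, and the source may have more. Where it says the series, first, only, none or still open, it means among the compounds named here.

Of the compounds shown here, three sharing one core have been measured in a functional assay on HepG2 cells (Homo sapiens) for inhibition, read by MTT assay, with a stated time of 72 h; on this read-out lower numbers stand for stronger inhibition and higher numbers for weaker inhibition. Compound 1 `CN(C(=O)NC(=O)c1ccccc1F)c1nc(C(F)(F)F)c(C(=O)N/N=C/c2ccc(C(F)(F)F)cc2)s1` gives 4.56 ug/mL, compound 2 `CN(C(=O)NC(=O)c1ccc(Cl)cc1Cl)c1nc(C(F)(F)F)c(C(=O)N/N=C/c2ccc(C(F)(F)F)cc2)s1` gives 12.4 ug/mL, and compound 3 `CN(C(=O)NC(=O)c1ccc(F)c(F)c1)c1nc(C(F)(F)F)c(C(=O)N/N=C/c2ccc(C(F)(F)F)cc2)s1` gives 6.26 ug/mL. The three differ only in the ring on the carbonyl carbon, and the steps between them are small: a 2.7-fold higher number from compound 1 to compound 2 (0.43 log units; beyond the scatter), a 1.4-fold higher number from compound 1 to compound 3 (0.14 log units; within the scatter), and a 2.0-fold lower number from compound 2 to compound 3 (0.30 log units; within the scatter). Compound 3 therefore sits among the others without standing apart from either one within the usual scatter.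

Compound 4 `CN(C(=O)NC(=O)c1ccc(F)c(F)c1)c1nc(C(F)(F)F)c(C(=O)N/N=C/c2ccccc2C(F)(F)F)s1` keeps the ring of compound 3 on the carbonyl carbon and changes a different part of the molecule: 2-(trifluoromethyl)phenyl in place of 4-(trifluoromethyl)phenyl on a carbon with a double bond to nitrogen. None of the measured steps touches this position, so no measured pair bears directly on the change; the whole measured range spans only a modest step, which gives no reason to expect a large move in this assay either way. The expected step from compound 3 to compound 4 is a 1.2-fold higher number from compound 3 to compound 4 (0.08 log units; within the scatter), which lies within the scatter. Compound 4 is therefore estimated at 7.5 ug/mL in this assay, with a range from 3 ug/mL to 18 ug/mL.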

Compound 4, half-maximal inhibitory concentration: 10.4 ug/mL
Beside the measured number, compound 4's estimate is 1.4-fold (0.14 log units) below it; the measured number falls inside the stated range.
By their numbers in this assay, from the lowest: compounds 1, 3, 4 and 2 (each within the scatter of the next, the first and the last beyond it).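

In this assay, within the data shown here, this is the first measured change at the ring on the carbon with a double bond to nitrogen: 2-(trifluoromethyl)phenyl in place of 4-(trifluoromethyl)phenyl gives a 1.7-fold higher number from compound 3 to compound 4 (0.22 log units; within the scatter) and leaves the atoms the same, joined differently. That step lies within the scatter, so the two placements of the trifluoromethyl group cannot be told apart by this read-out, and this position accepts either one without a clear change in the number. The data shown offer no measurement that could account for the size of this step.

Going by these compounds, the move has been read on one background only, with 3,4-difluorophenyl on the carbonyl carbon, so it remains open whether it would read the same way with 2-fluorophenyl or 2,4-dichlorophenyl there. On these data alone, it also remains open whether a different group on this ring in place of trifluoromethyl, such as an amine or a carboxylic acid, would shift the number by more than the scatter.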